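Aryl exchange from compound 3 to compound 4

A few compounds are considered here, and "the series" means these few. Any claim that something is new, unique, unknown or untested is made for them only; others in the source may bear on it.

compound 1 `CC1(C)[C@H]2CC[C@]1(C)N(Cc1cn(-c3ccc(F)cc3)nn1)C(=O)C2`: 110 nM
compound 2 `CC1(C)[C@H]2CC[C@]1(C)N(Cc1cn(-c3cccc(Cl)c3)nn1)C(=O)C2`: 260 nM
compound 3 `COc1ccccc1-n1cc(CN2C(=O)C[C@@H]3CC[C@@]2(C)C3(C)C)nn1`: 120 nM

In a functional assay on PANC-1 cells (Homo sapiens) for inhibition, read by MTT assay, with a stated time of 24 h (on this read-out higher numbers stand for weaker inhibition and lower numbers for stronger inhibition), compound 3 gives 120 nM and sits level with compound 1, with a 1.1-fold higher number from compound 1 to compound 3 (0.04 log units; within the scatter). Compound 2 stands apart from it, with a 2.2-fold lower number from compound 2 to compound 3 (0.34 log units; beyond the scatter).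

The next compound to be measured is compound 4 `CC1(C)[C@H]2CC[C@]1(C)N(Cc1cn(-c3ccc(Br)cc3)nn1)C(=O)C2`. It carries 4-bromophenyl in place of 2-methoxyphenyl on an aromatic nitrogen. The place is that of every aryl exchange measured so far, so all three steps bear on it. They stay small: the exchange of 4-fluorophenyl for 2-methoxyphenyl gave a 1.1-fold higher number from compound 1 to compound 3 (0.04 log units; within the scatter), and the exchange for 3-chlorophenyl gave a 2.4-fold higher number from compound 1 to compound 2 (0.37 log units; beyond the scatter), a modest step. Among the measured compounds shown here, no bromine-bearing compound has been measured yet. The nearest group on hand is the 4-fluorophenyl of compound 1, which has 110 nM, while compound 2 shows that a halogen-bearing aryl can also give a higher number, 260 nM.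

In this assay the expected result is a 1.2-fold higher number from compound 3 to compound 4 (0.07 log units; within the scatter), which would be no real shift beyond the scatter. The estimated value for compound 4 is 140 nM, with an expected range of 65 nM to 300 nM.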

Compound 4, half-maximal inhibitory concentration: 200 nM
Compound 4: the middle estimate sits 1.4-fold (0.15 log units) below what was measured, and the stated range covers the measured number.
By their numbers in this assay, from the lowest: compounds 1, 3, 4 and 2 (each within the scatter of the next, the first and the last beyond it).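

In this assay the 4-bromophenyl group separates from none of the three earlier aryl groups: the exchange for 4-fluorophenyl (a 1.8-fold higher number from compound 1 to compound 4 (0.26 log units; within the scatter)), the exchange for 2-methoxyphenyl (a 1.7-fold higher number from compound 3 to compound 4 (0.22 log units; within the scatter)) and the exchange for 3-chlorophenyl (a 1.3-fold lower number from compound 2 to compound 4 (0.11 log units; within the scatter)) all stay within the scatter. The earlier compounds shown here suggested two separate levels at this place, with compound 2 apart from compound 1 and compound 3, but compound 4 lies within the scatter of all three and so fills that gap, leaving the four aryl groups as one continuous run of values. Among the compounds shown here, the bromo-for-fluoro step is also the first exchange here that changes only the halogen, and the exchange from 2-methoxyphenyl, which gives up the one hydrogen-bond acceptor counted on that group, likewise produces no shift beyond the scatter.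

As far as these compounds go, all four compounds carry a substituted phenyl on the ring nitrogen, so it stays open how this place responds to a saturated cyclohexyl, or to a phenyl bearing an amine or a carboxylic acid. Nothing on hand accounts for the differences among these aryl groups.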